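Deprotection of the amine in the combretastatin-like benzyl ether series

The source may report more compounds than this note shows. Statements on the series, on what has been measured and on what is new or still open speak of the compounds shown alone.

Compound 2 `COc1ccc(/C=C\c2cc(OC)c(OC)c(OC)c2)cc1OCc1ccc(CN2CCCCC2C(=O)NCCNC(=O)OC(C)(C)C)cc1` in an ADME assay on HEK293 cells (Homo sapiens) for cytotoxicity, read by CCK-8 assay, with a stated time of 48 h (on this read-out higher numbers stand for weaker inhibition and lower numbers for stronger inhibition), gives 48000 nM. Compound 1 `COc1ccc(/C=C\c2cc(OC)c(OC)c(OC)c2)cc1OCc1ccc(C=O)cc1` in this assay gives 46000 nM, and the two values lie within the usual scatter of each other, so neither can be set apart. Compound 3 `COc1ccc(/C=C\c2cc(OC)c(OC)c(OC)c2)cc1OCc1ccc(CN2CCCCC2C(=O)NCCN)cc1` is not yet measured. It differs from compound 2 by hydrogen in place of tert-butoxycarbonyl on an amine nitrogen. Among the compounds with values here, no measured step of this kind exists, so the expected step in this assay is small and without a clear direction, not beyond the scatter. For compound 3 the estimated value is 40000 nM (range 18000 nM to 90000 nM), which corresponds to an expected step of a 1.2-fold lower number from compound 2 to compound 3 (0.08 log units; within the scatter).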

Compound 3, half-maximal inhibitory concentration: > 50000 nM
Compound 3: only a limit was reported (the forecaster's own chance of this, stated with the estimate: 10%); middle value at least 1.2-fold (0.09 log units) from the limit.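

Replacing tert-butoxycarbonyl with hydrogen on this amine nitrogen gives the only read on this position: in this assay, compound 3 gives > 50000 nM, which is a limit of the assay and not a number. The change reads as an at least 1.0-fold higher number from compound 2 to compound 3 (0.01 log units; that floor lies within the scatter), so the free 2-aminoethyl end brings no stronger inhibition of these cells. How far the true value lies past that floor cannot be read: the limit of > 50000 nM in this assay, at which 1 of the 3 values shown sits.

Still open, going by these compounds, is whether an acetyl group on this amine, a carboxylic acid or a longer chain in place of the 2-aminoethyl end would bring a value clear of the limit in this assay.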